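Swapping Chlorines for Methoxy Groups on a Benzylamine Arm

A few compounds are considered here, and "the series" means these few. Any claim that something is new, unique, unknown or untested is made for them only; others in the source may bear on it.

Compound 1 `Nc1cc(N)c2nc(-c3ccccc3)c(Oc3ccc(Cl)c(Cl)c3)nc2c1`: 87100 nM
Compound 2 `CCOC(=O)[C@H](CCC(=O)O)NC(=O)c1ccc(CNc2nc3cc(N)cc(N)c3nc2-c2ccccc2)cc1`: 37200 nM
Compound 3 `Nc1cc(N)c2nc(-c3ccccc3)c(NCc3ccc(Cl)c(Cl)c3)nc2c1`: 15800 nM

Of the compounds shown here, three built on the same diamino core have been tested in a functional assay on UACC-257 cells (Homo sapiens) for inhibition, read by sulforhodamine B assay, with a stated time of 48 h; a higher number here means a weaker inhibitor of growth, a lower number a stronger inhibitor of growth. Compound 1 carries its 3,4-dichlorophenyl group through an oxygen and gives 87100 nM. Compound 2 carries a larger benzylamine arm and gives 37200 nM. Compound 3 gives 15800 nM, the lowest of the three numbers; its gap to compound 2 and its gap to compound 1 both lie beyond the usual scatter, so compound 3 is the strongest growth inhibitor among the compounds measured here.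

Compound 4 `COc1ccc(CNc2nc3cc(N)cc(N)c3nc2-c2ccccc2)cc1OC` has not yet been measured. It differs from compound 3 in one place: 3,4-dimethoxyphenyl in place of 3,4-dichlorophenyl on a saturated chain carbon bound to a nitrogen on an aromatic ring. Among the compounds with values here, no measured pair shows exactly this exchange, so the expectation rests on the spread of the three known values. Since compound 2, which also changes only the benzyl substituent, sits above compound 3, a moderate rise in the number is expected, while a result within the scatter of compound 3 cannot be ruled out. The step from compound 3 to compound 4 in this assay is estimated at a 1.9-fold higher number from compound 3 to compound 4 (0.28 log units; within the scatter). Compound 4 is expected to give about 30000 nM, most likely between 8000 nM and 100000 nM.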

Compound 4, concentration for total growth inhibition: 26900 nM
Compound 4: the middle estimate sits 1.1-fold (0.05 log units) above what was measured, within the range that was stated.
By their numbers in this assay, from the lowest: compounds 3, 4 and 2 (each within the scatter of the next, the first and the last beyond it); then compound 1.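

In this assay, putting 3,4-dimethoxyphenyl in place of 3,4-dichlorophenyl on a saturated chain carbon bound to a nitrogen on an aromatic ring gives a 1.7-fold higher number from compound 3 to compound 4 (0.23 log units; within the scatter) and so produces no difference that can be told apart from ordinary repeat variation. Within the data shown here, the earlier compounds offered no pair differing in one place, which makes this the first direct reading at this position: the entering group holds 10 heavy atoms against 8 and 2 hydrogen-bond acceptors against 0, yet the measured number does not separate the two compounds. No measurement of any property of these two groups comes with the result, and the reason for it remains unknown.

A single exchange cannot show whether this position accepts most groups or whether these two simply happen to give similar values. Going by these compounds, it remains open whether an amine or a carboxylic acid on the benzyl ring, or a longer chain joining that ring to the nitrogen, would give a number clearly different from those of compound 3 and compound 4.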